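Sulfonyl group on the ring nitrogen of compound 3

The source may report more compounds than this note shows. Statements on the series, on what has been measured and on what is new or still open speak of the compounds shown alone.

In a functional assay on QGY-7703 cells (Homo sapiens) for cytotoxicity, read by MTT assay, with a stated time of 24 h (a lower number here means a stronger inhibitor, a higher number a weaker inhibitor), compound 3 (`O=C1/C(=C/c2ccncc2)CNC/C1=C\c1ccccc1F`) gives 14200 nM and stands within the scatter of compound 2 (`O=C1/C(=C/c2cccnc2)CNC/C1=C\c1ccccc1F`), which gives 8890 nM in the same read-out. Compound 1 (`CN1C/C(=C\c2ccncc2)C(=O)/C(=C/c2cc([N+](=O)[O-])ccc2F)C1`) at 5700 nM lies lower than compound 3, beyond the scatter.

The change to compound 4 (`N#Cc1ccc(S(=O)(=O)N2C/C(=C\c3ccncc3)C(=O)/C(=C/c3ccccc3F)C2)cc1`) puts (4-cyanophenyl)sulfonyl in place of hydrogen on an amine nitrogen in a ring. Among the measured compounds shown here, the only measured step, a 1.6-fold higher number from compound 2 to compound 3 (0.20 log units; within the scatter), swaps one pyridinyl group for another and leaves this nitrogen untouched, so no measured step tests the change directly. Compound 1 also differs from compound 3 on that nitrogen, but it differs elsewhere too, so compound 1 at 5700 nM is only a weak pointer towards a lower number.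

On that thin basis, the expected move in this assay is a 2.8-fold lower number from compound 3 to compound 4 (0.45 log units; beyond the scatter) with wide uncertainty. Compound 4 is estimated at 5000 nM within an expected range of 1500 nM to 14000 nM as a working figure.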

Compound 4, half-maximal inhibitory concentration: 8500 nM
Compound 4: middle estimate off by 1.7-fold (0.23 log units), on the low side; the measured number falls inside the stated range.
By their numbers in this assay, from the lowest: compounds 1, 4, 2 and 3 (each within the scatter of the next, the first and the last beyond it).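

In this assay, the amine nitrogen in the ring now has its first direct reading, and the step is a 1.7-fold lower number from compound 3 to compound 4 (0.22 log units; within the scatter) with (4-cyanophenyl)sulfonyl in place of hydrogen. A group of 11 heavy atoms, carrying a six-membered aromatic ring, can therefore sit on this nitrogen without a shift beyond the scatter, which compound 1 could not show, as it differs from compound 3 in more than one place. No measured evidence accounts for this result.

Still open, as far as these compounds go, is whether other groups on this nitrogen, such as acetyl, benzyl or methanesulfonyl, would read the same with the rest of compound 3 unchanged. Also open, from the compounds shown here alone, is what the nitrile contributes, which a plain phenylsulfonyl group or a carboxylic acid in its place would help to separate from the sulfonyl link.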